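Swapping Methoxy for Chloro on the Unvaried Aromatic Ring

The source may report more compounds than this note shows. Statements on the series, on what has been measured and on what is new or still open speak of the compounds shown alone.

Measured in a functional assay on U-87MG ATCC cells for antiproliferative activity against U-87 MG (Homo sapiens), read by MTT assay, with a stated time of 48 h; a higher number here means a weaker inhibitor, a lower number a stronger inhibitor:
- compound 1 `COc1ccc(-c2nc(C)c(C(=O)CSc3nc(N)c(C#N)c(-c4ccc(Cl)cc4)n3)s2)cc1`: 4540 nM
- compound 2 `COc1ccc(-c2nc(C)c(C(=O)CSc3nc(N)c(C#N)c(-c4ccccc4)n3)s2)cc1`: 8540 nM
- compound 3 `COc1ccc(-c2nc(C)c(C(=O)CSc3nc(N)c(C#N)c(-c4ccc(OC)cc4)n3)s2)cc1`: 1560 nM

Compound 3 has the lowest number of the three, and its steps to both others lie beyond the scatter. Compound 4 `COc1ccc(-c2nc(SCC(=O)c3sc(-c4ccc(Cl)cc4)nc3C)nc(N)c2C#N)cc1`, not yet measured, differs from compound 3 by chloro in place of methoxy on an aromatic carbon, a change from 4-methoxyphenyl to 4-chlorophenyl. Among the measured compounds shown here, this falls on the 4-methoxyphenyl that stays the same across compounds 1, 2 and 3, not on the ring that varies among them, so no measured step tests this site directly. The nearest evidence is the same pair of groups on the varied ring, where methoxy in place of chloro gave a 2.9-fold lower number from compound 1 to compound 3 (0.46 log units; beyond the scatter). Methoxy in place of hydrogen on that ring gave a 5.5-fold lower number from compound 2 to compound 3 (0.74 log units; beyond the scatter). Reversing the first of these suggests a modest rise in this assay, though the transfer between sites is uncertain. The expected change is a 1.8-fold higher number from compound 3 to compound 4 (0.25 log units; within the scatter). For compound 4 the estimated value is 2800 nM, with an expected range from 1000 nM to 7500 nM.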

Compound 4, half-maximal inhibitory concentration: 10600 nM
Estimate against measurement, compound 4: 3.8-fold (0.58 log units) below; the measured number lies above the stated range.
By their numbers in this assay, from the lowest: compound 3; then compounds 1, 2 and 4 (each within the scatter of the next, the first and the last beyond it).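

In this assay, replacing the 4-methoxyphenyl that stayed constant across compounds 1, 2 and 3 with 4-chlorophenyl gives a 6.8-fold higher number from compound 3 to compound 4 (0.83 log units; beyond the scatter) and so shows that this position, untested until now, responds to the change. The direction matches that on the varied ring, where a 2.9-fold lower number from compound 1 to compound 3 (0.46 log units; beyond the scatter) favoured methoxy over chloro, so in these compounds methoxy carries the lower number at both sites, and compound 3, with methoxy at both, has the lowest number of the four. Nothing measured here explains why this swap raises the number.

The compounds shown do not reveal how this position behaves with hydrogen in place of methoxy. They also leave open whether a longer ether such as ethoxy, or an amine, would keep or lower the number seen for compound 3.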